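A few compounds are considered here, and "the series" means these few. Any claim that something is new, unique, unknown or untested is made for them only; others in the source may bear on it.

Compound 1 `O=C(Nc1nnc(-c2ccc3c(c2)OCCO3)s1)c1ccccc1` is the reference point here, and it stands at a limit. In a functional assay on HeLa cells (Homo sapiens) for antiproliferative activity, read by MTT assay, with a stated time of 48 h (a lower number here means that less compound is needed, a higher number that more compound is needed for the effect), compound 1 gives > 100 ug/mL, which is a limit of the assay and not a number. Going by the values given here, compound 2 `Cc1ccccc1C(=O)Nc1nnc(-c2ccc3c(c2)OCCO3)s1`, the only other measured compound, gives > 100 ug/mL, and this too is a limit. Among the compounds with values here, the one measured step, a step that the two limits leave unreadable from compound 1 to compound 2, therefore has no size that can be read, and all the data show is the limit of > 100 ug/mL in this assay, at which 2 of the 2 values shown sit. That step is also a different change, methyl in place of hydrogen on an aromatic carbon.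

Compound 3 `O=C(CCc1ccccc1)Nc1nnc(-c2ccc3c(c2)OCCO3)s1` keeps the shared core and carries phenethyl in place of phenyl on a carbonyl carbon. The measured step offers neither a size nor a direction to carry over, so no step beyond the scatter is expected in this assay. The expected step is a number no higher from compound 1 to compound 3 (the limit leaves the size open), and a further limit is the likeliest report. For compound 3 the estimated value is 100 ug/mL, with an expected range from 30 ug/mL to 300 ug/mL.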

Compound 3, half-maximal effective concentration: 32.5 ug/mL
Beside the measured number, compound 3's estimate is 3.1-fold (0.49 log units) above it; measured number inside the range.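

In this assay the place on the carbonyl carbon now gives a step that can be read, which the earlier pair did not: phenethyl in place of phenyl gives an at least 3.0-fold lower number from compound 1 to compound 3 (0.48 log units; beyond the scatter) and so moves the number in the lower direction. Phenethyl in place of 2-methylphenyl at the same place gives an at least 3.0-fold lower number from compound 2 to compound 3 (0.48 log units; beyond the scatter) in the same direction, so both changes that bring in phenethyl lie beyond the scatter. Going by these compounds alone, compound 3 is the only compound of the three with a value that is a number, and the size of each step stays open on one side, since each starts from a limit: the limit of > 100 ug/mL in this assay, at which 2 of the 3 values shown sit.

The compounds shown leave open whether a longer chain carrying the phenyl, or a chain ending in an amine or a carboxylic acid in place of the phenyl, would move the number further from that of compound 3 in this assay at this place. They also leave open how far compound 1 and compound 2 really lie from compound 3, and whether a methyl on the phenyl of phenethyl would change the number at all.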